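This account rests on a few compounds, and the source may have more. Where it says the series, first, only, none or still open, it means among the compounds named here.

Among the compounds with values here, compound 1 `CCc1nn2c(-c3ccc(OC)cc3Cl)cccc2c1N(CC1CC1)CC1CC1` is one of two compounds measured in a functional assay on HEK293 cells for antagonist activity at corticotropin-releasing factor receptor 1 (Homo sapiens), read by fluorescence and cAMP accumulation, with a stated time of 30 min; a higher number here means a weaker inhibitor, a lower number a stronger inhibitor. In this assay, within the data shown here, compound 1 gives 100 nM, the higher of the two numbers known so far. Compound 2 `CCc1nn2c(-c3c(OC)cc(C)cc3OC)cccc2c1N(CC1CCOCC1)CC1CC1` gives 20 nM in this assay, a lower number than that of compound 1, and the gap between the two lies beyond the usual scatter of repeated measurements. Among the measured compounds shown here, compound 2 differs from compound 1 in more than one place, so the pair shows only that the number of compound 2 is the lower one.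

Compound 3 `CCCN(CCC)c1c(CC)nn2c(-c3ccc(OC)cc3Cl)cccc12` has not yet been measured in this assay. It differs from compound 1 in a single place: dipropylamino in place of bis(cyclopropylmethyl)amino on an aromatic carbon. Everything else in compound 1, including its shared core, is kept.

For the measured compounds named here, no step between measured compounds that differ only at this place is available, so the expectation rests on compound 1 alone. The expected step is a 1.4-fold lower number from compound 1 to compound 3 (0.15 log units; within the scatter), a small move toward a lower number that may well stay within the scatter. Compound 3 is therefore estimated at 70 nM, with a range from 25 nM to 250 nM.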

Compound 3, half-maximal inhibitory concentration: 200 nM
For compound 3 the middle estimate is 2.9-fold (0.46 log units) below the measured one, and the stated range covers the measured number.
By their numbers in this assay, from the lowest: compound 2; then compounds 1 and 3 (each within the scatter of the next).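

Within the data shown here, for the first time, a single change at this position can be read on its own: with the rest of compound 1 kept, dipropylamino in place of bis(cyclopropylmethyl)amino on an aromatic carbon gives a 2.0-fold higher number from compound 1 to compound 3 (0.30 log units; within the scatter) in this assay. The entering group has no ring and 7 heavy atoms, whereas the departing group has 2 three-membered rings and 9 heavy atoms, yet this pair does not separate the two groups beyond the scatter, so the two three-membered rings are not required for a number in this range on this core. No measured property of either group accompanies this pair, and the result therefore stays without an explanation.

Still open, from the compounds shown here alone, is whether a longer chain such as dibutylamino, a shorter one such as dimethylamino, or a morpholine ring at this place would stay equally close to compound 1 or move clearly away from it. Also open, going by these compounds, is whether the same exchange of amino groups would give a similar step when the other substituents of compound 2 are present.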